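A few compounds are considered here, and "the series" means these few. Any claim that something is new, unique, unknown or untested is made for them only; others in the source may bear on it.

Measured so far in a physicochemical assay for lipophilicity, using the shake flask method, in phosphate buffer, measured as octanol-water partition, at pH 7.4; a higher number here means a more lipophilic compound, a lower number a more polar compound:
compound 1 `Cc1cn([C@H]2CCCN([C@H](CC(C)C)c3ccc(C(=O)O)c(Oc4cccc(Cl)c4)c3F)C2)c(=O)[nH]c1=O`: 0.92
compound 2 `CCC[C@@H](c1ccc(C(=O)O)c(Oc2cccc(Cl)c2)c1OC)N1CCC[C@H](n2cc(C)c(=O)[nH]c2=O)C1`: 0.13
compound 3 `Cc1cn([C@H]2CCCN(Cc3ccc(C(=O)O)c(Oc4cccc(Cl)c4)c3F)C2)c(=O)[nH]c1=O`: -0.59

Compound 3, at -0.59, stands lowest of the three in this assay. Compound 4 `CCC[C@@H](c1ccc(C(=O)O)c(Oc2cccc(Cl)c2)c1F)N1CCC[C@H](n2cc(C)c(=O)[nH]c2=O)C1` has not yet been measured. It differs from compound 3 in one place: propyl in place of hydrogen on a saturated chain carbon bound to an amine nitrogen in a ring and an aromatic carbon. This is propyl in place of hydrogen on a saturated chain carbon bound to an amine nitrogen in a ring and an aromatic carbon.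

Within the data shown here, the one measured step at this carbon reads a number 1.51 log units lower from compound 1 to compound 3 (beyond the scatter), with hydrogen in place of isobutyl. Taken in reverse, this large step points to a large rise when hydrogen gives way to a chain. Propyl is not isobutyl, however, so the full size of that step need not carry over. Compound 2, which also carries propyl on that carbon but differs elsewhere in the core, gives 0.13. A rise somewhat smaller than the one seen with isobutyl, though still large, is therefore expected. The expected change is a number 1.09 log units higher from compound 3 to compound 4 (beyond the scatter). Compound 4 is estimated at 0.5, with an expected range of 0.1 to 0.9.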

Compound 4, distribution coefficient: 0.51
Compound 4: middle estimate off by 0.01 log units, on the low side; the range from low to high includes it.
By their numbers in this assay, from the lowest: compound 3; then compound 2; then compound 4; then compound 1.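

In this assay, propyl in place of hydrogen on a saturated chain carbon bound to an amine nitrogen in a ring and an aromatic carbon gives a number 1.10 log units higher from compound 3 to compound 4 (beyond the scatter) and thus a large step, so the large change at this carbon is no longer tied to isobutyl alone. On the shared core, compound 4 gives 0.51 against 0.92 for compound 1, which places the isobutyl compound higher than the propyl compound, and both stand well clear of the unsubstituted compound 3. Among these compounds, the result also gives a first reading at a second site, with propyl held constant: fluoro in place of methoxy on an aromatic carbon gives a number 0.38 log units higher from compound 2 to compound 4 (beyond the scatter) and so a modest step, smaller in class than the step at the chain carbon.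

Nothing at hand explains either step. As far as these compounds go, with only hydrogen, propyl and isobutyl at the chain carbon, it remains open whether a longer chain, a cyclopropyl group or an added amine would follow the same trend, and whether the fluoro and methoxy difference would keep its size with isobutyl or hydrogen on that carbon.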